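Removing the trifluoromethyl from compound 2

This account rests on a few compounds, and the source may have more. Where it says the series, first, only, none or still open, it means among the compounds named here.

Going by the values given here, two analogues of the shared core carry numbers so far. Compound 1 `C#CCSc1nc(Nc2ccc(OC)cc2)c(C#N)c(-c2ccccc2)n1` gives 35600 nM in a functional assay on MCF7 cells (Homo sapiens) for inhibition, read by MTT assay, with a stated time of 72 h; a higher number here means a weaker inhibitor, a lower number a stronger inhibitor. Compound 2 `N#Cc1c(Nc2cccc(C(F)(F)F)c2)nc(SCc2cn(Cc3ccccc3Cl)nn2)nc1-c1ccccc1` gives 12600 nM in this assay, the lower of the two numbers, its gap to compound 1 lying beyond the scatter. Compound 3 `N#Cc1c(Nc2ccccc2)nc(SCc2cn(Cc3ccccc3Cl)nn2)nc1-c1ccccc1` is not yet measured; it differs from compound 2 by hydrogen in place of trifluoromethyl on an aromatic carbon. Among the compounds with values here, no step between measured compounds covers this change, so only a small weakening, at most near the edge of the scatter, is expected: a 1.6-fold higher number from compound 2 to compound 3 (0.20 log units; within the scatter). Compound 3 is estimated at 20000 nM in this assay, with a range of 8000 nM to 60000 nM.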

Compound 3, half-maximal inhibitory concentration: > 64000 nM
Compound 3 was reported as a limit; the forecaster's own chance of this, stated with the estimate: 15%; middle value at least 3.2-fold (0.50 log units) away from the limit.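

Removing the trifluoromethyl gives the series its first single-change step, and the change is not neutral at this position: in this assay there is an at least 5.0-fold higher number from compound 2 to compound 3 (0.70 log units; beyond the scatter). Compound 3 is a limit and not a number: the limit of > 64000 nM in this assay, at which 1 of the 3 values shown sits. The step is therefore a lower bound, and the true size of the loss on going from 3-(trifluoromethyl)phenyl to phenyl cannot be read.

On these data alone, whether this depends on trifluoromethyl itself or on any group at this place stays open. A methyl or a carboxylic acid on the same aromatic carbon would separate the two.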